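The source may hold more compounds than are shown below. What is called first, only, known or untested is meant among the compounds shown, and "the series" means these compounds.

Of the compounds shown here, three built on one shared core have been tested in a functional assay on SW480 cells (Homo sapiens) for antiproliferative activity, read by MTT assay, with a stated time of 48 h; on this read-out higher numbers stand for weaker inhibition and lower numbers for stronger inhibition. Compound 1 `CCCCCC(CCO)n1cnc2c(OC)ncnc21` returns only a limit of this assay, > 50000 nM. Compound 2 `CCCCCCCC(CCO)n1cnc2c(OC)ncnc21` gives 23900 nM in this assay, and compound 3 `CCCCCCCCCC(CCO)n1cnc2c(OC)ncnc21` gives 3250 nM. Of the two numbers shown, compound 3 stands lowest; its nearest neighbour is compound 2, separated by a 7.4-fold lower number from compound 2 to compound 3 (0.87 log units; beyond the scatter), and the remaining value is a limit. The other steps run the same way, an at least 2.0-fold lower number from compound 1 to compound 2 (0.32 log units; beyond the scatter) and an at least 15-fold lower number from compound 1 to compound 3 (1.18 log units; beyond the scatter), each by ethyl or butyl in place of hydrogen on a saturated chain carbon, six bonds along the chain from an aromatic nitrogen.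

Compound 4 `CCCCCCCCCCCC(CCO)n1cnc2c(OC)ncnc21` has not yet been measured. It differs from compound 3 by ethyl in place of hydrogen on a saturated chain carbon, ten or more bonds along the chain from an aromatic nitrogen. All three measured steps bear on this change, and each lowered the number in this assay, the last by a 7.4-fold lower number from compound 2 to compound 3 (0.87 log units; beyond the scatter). A further drop is therefore expected, though possibly smaller; the estimated step is a 3.6-fold lower number from compound 3 to compound 4 (0.56 log units; beyond the scatter). Compound 4 is expected to give about 900 nM in this assay, most likely between 250 nM and 3500 nM.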

Compound 4, half-maximal inhibitory concentration: 9700 nM
Estimate against measurement, compound 4: 11-fold (1.03 log units) below, outside the stated range (above it).
By their numbers in this assay, from the lowest: compound 3; then compound 4; then compound 2. At a limit, above all of these: compound 1.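

In this assay, lengthening the chain no longer keeps lowering the number: the same ethyl in place of hydrogen on a saturated chain carbon gives a 3.0-fold higher number from compound 3 to compound 4 (0.47 log units; beyond the scatter). The trend therefore turns around, and compound 3 has the best chain length of those shown, although part of the gain remains, with a 2.5-fold lower number from compound 2 to compound 4 (0.39 log units; beyond the scatter) and an at least 5.1-fold lower number from compound 1 to compound 4 (0.71 log units; beyond the scatter). An added ethyl thus has no fixed effect in this series, and its outcome depends on the chain it extends: the same change on two cores in this assay, an at least 2.0-fold lower number (0.32 log units; beyond the scatter) from compound 1 to compound 2 and a 3.0-fold higher number (0.47 log units; beyond the scatter) from compound 3 to compound 4, at least 6.2-fold (0.79 log units) apart, beyond the scatter of two such steps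

Going by these compounds, whether a still longer chain would raise the number further remains open. So does whether an amine or a carboxylic acid in place of the hydroxyl would preserve the activity of compound 3.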